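A few compounds are considered here, and "the series" means these few. Any claim that something is new, unique, unknown or untested is made for them only; others in the source may bear on it.

In a functional assay on HeLa cells (Homo sapiens) for antiproliferative activity, read by MTT assay, with a stated time of 48 h (a lower number here means a stronger inhibitor, a higher number a weaker inhibitor), compound 1 `Fc1ccc(-c2nn(-c3ccccc3)cc2-c2nc3ccccc3[nH]2)cc1` gives 2330 nM, compound 2 `Fc1ccc(-c2nn(-c3ccccc3)cc2-c2nc3cc(Br)ccc3[nH]2)cc1` gives 4940 nM and compound 3 `COc1ccc2[nH]c(-c3cn(-c4ccccc4)nc3-c3ccc(F)cc3)nc2c1` gives 7510 nM. The measured steps show a 2.1-fold higher number from compound 1 to compound 2 (0.33 log units; beyond the scatter), which is beyond the scatter, and a 1.5-fold higher number from compound 2 to compound 3 (0.18 log units; within the scatter), which is within it. Compound 4 `COc1ccc(-c2nn(-c3ccccc3)cc2-c2nc3cc(Br)ccc3[nH]2)cc1` changes compound 2 at a single place: methoxy in place of fluoro on an aromatic carbon. Within the data shown here, this is 4-fluorophenyl to 4-methoxyphenyl, and no measured step touches that place. The nearest guide is methoxy added at another place, a modest 3.2-fold higher number from compound 1 to compound 3 (0.51 log units; beyond the scatter). Such indirect evidence supports expecting no step beyond the scatter in this assay, with any drift slightly upward. That means an expected 1.1-fold higher number from compound 2 to compound 4 (0.05 log units; within the scatter). For compound 4 the estimated value is 5500 nM, with an expected range of 2000 nM to 14000 nM.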

Compound 4, half-maximal inhibitory concentration: 1060 nM
Compound 4: the middle estimate sits 5.2-fold (0.72 log units) above what was measured; measured number below the stated range.
By their numbers in this assay, from the lowest: compound 4; then compound 1; then compounds 2 and 3 (each within the scatter of the next).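

In this assay, among these compounds, replacing 4-fluorophenyl with 4-methoxyphenyl gives a 4.7-fold lower number from compound 2 to compound 4 (0.67 log units; beyond the scatter), the only measured change at this position. Methoxy therefore does not shift the number the same way everywhere: added at another place on the core, it gave a 3.2-fold higher number from compound 1 to compound 3 (0.51 log units; beyond the scatter). No measurement shown here explains this difference. Going by these compounds, it remains open how an amine or a longer chain, such as ethoxy, would behave at this position. On these data alone, it is also open whether the same swap lowers the number when the bromo group of compound 2 is absent.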